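The source may hold more compounds than are shown below. What is called first, only, known or untested is meant among the compounds shown, and "the series" means these compounds.

Measured in a functional assay on RAW264.7 cells (Mus musculus) for inhibition; on this read-out lower numbers stand for stronger inhibition and higher numbers for weaker inhibition:
Compound 1 `O=C(NS(=O)(=O)c1ccccc1)c1cccnc1`: 9500 nM
Compound 2 `O=C(NS(=O)(=O)c1ccccc1)c1cncc(C(=O)NS(=O)(=O)c2ccccc2)c1`: 2600 nM
Compound 3 `O=C(NS(=O)(=O)c1ccc(F)cc1)c1ccncc1`: 9200 nM

Compound 3, at 9200 nM, lies within the scatter of compound 1, while its number is higher than that of compound 2 by more than the scatter. Compound 4 `O=C(NS(=O)(=O)c1ccc(Cl)cc1)c1ccncc1` has chloro in place of fluoro on an aromatic carbon, para to a large group (chloro in place of fluoro on an aromatic carbon). Going by the values given here, no measured pair here shows what such an exchange does, so the anchor is compound 3 at 9200 nM. The expected change, a 1.2-fold lower number from compound 3 to compound 4 (0.09 log units; within the scatter), is not expected to exceed the scatter in either direction. For compound 4 the estimated value is 7500 nM, with an expected range from 3000 nM to 18000 nM.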

Compound 4, half-maximal inhibitory concentration: 8900 nM
Estimate against measurement, compound 4: 1.2-fold (0.07 log units) below, within the range that was stated.
By their numbers in this assay, from the lowest: compound 2; then compounds 4, 3 and 1 (each within the scatter of the next).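

In this assay, chloro in place of fluoro on an aromatic carbon, para to a large group, gives a 1.0-fold lower number from compound 3 to compound 4 (0.01 log units; within the scatter), which makes this the first pair shown that differs in one place. At this place, the two groups cannot be told apart on this read-out. Nothing available accounts for this result. Still open, from the compounds shown here alone, is whether an amine, a carboxylic acid or a longer chain at this place would move the number beyond the scatter. Also open, going by these compounds, is whether the same exchange gives a similar result on the core of compound 1.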